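Swapping the aryl group on the triazole nitrogen of a sesquiterpenoid oxime

This account rests on a few compounds, and the source may have more. Where it says the series, first, only, none or still open, it means among the compounds named here.

Compound 1 `COc1cccc(-n2cc(CO/N=C3\CC[C@]4(C)[C@@H](CC/C=C(\C)CC/C=C(\C)CCC=C(C)C)[C@](C)(O)CC[C@H]4C3(C)C)nn2)c1` carries a 3-methoxyphenyl group on an aromatic nitrogen of a five-membered aromatic ring with 3 nitrogen. In a functional assay on HeLa cells (Homo sapiens) for cytotoxicity, read by MTT assay, with a stated time of 48 h (a lower number here means a stronger inhibitor, a higher number a weaker inhibitor), compound 1 gives 22900 nM, the highest of the three numbers available, though both neighbours sit within the scatter of it. Compound 2 `CC(C)=CCC/C(C)=C/CC/C(C)=C/CC[C@@H]1[C@@]2(C)CC/C(=N\OCc3cn(-c4cccc(C(F)(F)F)c4)nn3)C(C)(C)[C@@H]2CC[C@@]1(C)O` gives 12500 nM and compound 3 `CC(C)=CCC/C(C)=C/CC/C(C)=C/CC[C@@H]1[C@@]2(C)CC/C(=N\OCc3cn(-c4cccc(O)c4)nn3)C(C)(C)[C@@H]2CC[C@@]1(C)O` gives 13500 nM, so that the steps of a 1.8-fold lower number from compound 1 to compound 2 (0.26 log units; within the scatter) and a 1.7-fold lower number from compound 1 to compound 3 (0.23 log units; within the scatter) change nothing that can be trusted. Compound 4 `CC(C)=CCC/C(C)=C/CC/C(C)=C/CC[C@@H]1[C@@]2(C)CC/C(=N\OCc3cn(-c4ccncc4)nn3)C(C)(C)[C@@H]2CC[C@@]1(C)O` is the next variation at the same site: pyridin-4-yl in place of 3-methoxyphenyl on an aromatic nitrogen. The two measured steps from compound 1 are the ones that bear on this change, since each also replaces a substituent on the ring bound to that aromatic nitrogen, and each stayed within the scatter. On that basis the step from compound 1 to compound 4 is expected to be small, a 1.3-fold lower number from compound 1 to compound 4 (0.13 log units; within the scatter), with no clear direction. Compound 4 is therefore estimated at 17000 nM in this assay, with a plausible range from 7000 nM to 45000 nM.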

Compound 4, half-maximal inhibitory concentration: 18800 nM
Compound 4: the middle estimate sits 1.1-fold (0.04 log units) below what was measured, and the stated range covers the measured number.
By their numbers in this assay, from the lowest: compounds 2, 3, 4 and 1 (each within the scatter of the next).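

In this assay the new change is of a different kind from the earlier ones: it places a hetero atom in the six-membered aromatic ring itself and removes heavy atoms, yet the steps stay within the scatter, at a 1.2-fold lower number from compound 1 to compound 4 (0.09 log units; within the scatter) and a 1.4-fold higher number from compound 3 to compound 4 (0.14 log units; within the scatter) and a 1.5-fold higher number from compound 2 to compound 4 (0.18 log units; within the scatter). Across the four aryl groups on this aromatic nitrogen, no group can therefore be ranked above another, whether the ring holds carbon only or a ring nitrogen. No measurement offered here accounts for how close these numbers lie.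

Going by these compounds, whether an amine or a carboxylic acid on the aromatic ring, or a longer alkyl chain in place of the ring, would move the number beyond the scatter remains open. On these data alone, all four compounds share the same core, so the effect of a change there is also open.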